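Three N-substituents, same outcome: where does a benzyl ester land?

The source may report more compounds than this note shows. Statements on the series, on what has been measured and on what is new or still open speak of the compounds shown alone.

Compound 1, `COc1ccc(-c2cc3c(OC)cc(OC)cc3n(C)c2=O)cc1`, gives 10000 nM in a functional assay on PC-3 cells (Homo sapiens) for cytotoxicity, read by colorimetric assay and MTT assay; on this read-out lower numbers stand for stronger inhibition and higher numbers for weaker inhibition.
Compound 2, `COc1ccc(-c2cc3c(OC)cc(OC)cc3n(CC#N)c2=O)cc1`, gives 10000 nM in this assay.
Compound 3, `COc1ccc(-c2cc3c(OC)cc(OC)cc3n(CC(=O)O)c2=O)cc1`, gives 10000 nM in this assay.

Compound 3 stands level with compound 1 and compound 2 at the digits shown. The steps of no change at the digits printed from compound 1 to compound 3 (within the scatter) and no change at the digits printed from compound 2 to compound 3 (within the scatter) both report no change beyond the scatter, as does no change at the digits printed from compound 1 to compound 2 (within the scatter).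

Compound 4, `COc1ccc(-c2cc3c(OC)cc(OC)cc3n(CCC(=O)OCc3ccccc3)c2=O)cc1`, has not yet been measured. It differs from compound 3 as follows: (benzyloxycarbonyl)methyl in place of carboxy on a saturated chain carbon bound to an aromatic nitrogen. The three measured steps all alter the group on the saturated chain carbon bound to the aromatic nitrogen, and none of them moved the read-out. The change to compound 4 sits at the same place, so the expectation is a step of no change at the digits printed from compound 3 to compound 4 (within the scatter), none beyond the scatter. Compound 4 is therefore estimated at 10000 nM, with a range from 4000 nM to 25000 nM.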

Compound 4, half-maximal inhibitory concentration: 10000 nM
Compound 4: middle estimate and measured number agree at the digits printed; low and high end bracket the measured number.
By their numbers in this assay, from the lowest: compounds 1, 2, 3 and 4 (each within the scatter of the next).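

In this assay, replacing carboxy with (benzyloxycarbonyl)methyl brings 11 heavy atoms in place of 3, adds a six-membered aromatic ring of carbon only and removes the hydrogen-bond donor, yet the step reads no change at the digits printed from compound 3 to compound 4 (within the scatter) without any shift. The comparisons with the nitrile and with the plain hydrogen agree (no change at the digits printed from compound 2 to compound 4 (within the scatter); no change at the digits printed from compound 1 to compound 4 (within the scatter)), so among these four compounds even this far larger, ring-bearing group on a saturated chain carbon bound to an aromatic nitrogen leaves the read-out level. Nothing available bears on why the values stay level.

On these data alone, whether an amine, an amide or a simple benzyl group at this place would shift the read-out stays open. So does whether changing the methoxy groups on the core would do so.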